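A Flipped Stereocentre on the Fluorocyclopropyl Amide

The compounds below may be only part of what the source reports. "The series", "measured", "known", "first", "only" and "open" are said of these compounds alone.

Compound 1, `CCCC(=O)N1CC2CC(C1)N2`, gives 350 nM in an assay on CHO cells for displacement of a labelled ligand from Neuronal acetylcholine receptor; alpha3/alpha6/beta2/beta3 (Homo sapiens), read by scintillation counting; on this read-out lower numbers stand for stronger inhibition and higher numbers for weaker inhibition.
Compound 2, `CC(C)C(=O)N1CC2CC(C1)N2`, gives 580 nM in this assay.
Compound 3, `O=C([C@H]1C[C@H]1F)N1CC2CC(C1)N2`, gives 27 nM in this assay.

Compound 3 holds the lowest number of the three in this assay. Its nearest neighbour is compound 1, with a 13-fold lower number from compound 1 to compound 3 (1.11 log units; beyond the scatter), and the furthest is compound 2, with a 21-fold lower number from compound 2 to compound 3 (1.33 log units; beyond the scatter); between the two open-chain amides the step of a 1.7-fold higher number from compound 1 to compound 2 (0.22 log units; within the scatter) lies within the scatter. Compound 4, `O=C([C@@H]1C[C@H]1F)N1CC2CC(C1)N2`, keeps every atom and bond of compound 3; the only difference is the two compounds have the same atoms and bonds; at least one stereo element is drawn with a configuration in one of them and without one in the other: 1 of 4 stereo elements differ; a stereocentre at a saturated ring carbon is drawn R in compound 3 and S in compound 4. Among the compounds with values here, none of the measured steps touches a stereocentre: all three compare different groups on the carbonyl carbon, so no measured pair says how the two fluorocyclopropyl diastereomers relate. The expectation for compound 4 in this assay therefore rests on compound 3 alone, and compound 4 is estimated to give 60 nM, within 15 nM to 300 nM. This expected step, a 2.2-fold higher number from compound 3 to compound 4 (0.35 log units; beyond the scatter), allows for some weakening while leaving open that the two isomers sit within the scatter of each other.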

Compound 4, inhibition constant: 43 nM
Compound 4: middle estimate off by 1.4-fold (0.14 log units), on the high side; measured number inside the range.
By their numbers in this assay, from the lowest: compounds 3 and 4 (each within the scatter of the next); then compounds 1 and 2 (each within the scatter of the next).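

In this assay, inverting this saturated ring carbon of the 2-fluorocyclopropyl amide gives no separation beyond the scatter: a 1.6-fold higher number from compound 3 to compound 4 (0.20 log units; within the scatter). The advantage over the open-chain amides is therefore not confined to compound 3, since it also appears in a 13-fold lower number from compound 2 to compound 4 (1.13 log units; beyond the scatter) and in an 8.1-fold lower number from compound 1 to compound 4 (0.91 log units; beyond the scatter). One caution about how the structures are drawn applies to reading this pair as two defined stereoisomers: the fact that one of compounds 3 and 4 is drawn with a defined configuration and the other without, at the place where they differ.

The compounds shown leave open whether the fluorine or the cyclopropyl ring carries the lower numbers, a question that a plain cyclopropyl amide would bear on. Within the data shown here, they also leave open how the configuration at the fluorine-bearing carbon acts, as this stereocentre is not the one that changes between compound 3 and compound 4.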